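From 2-methoxybenzyl to (pyridin-4-yl)methyl on the shared core

The compounds below may be only part of what the source reports. "The series", "measured", "known", "first", "only" and "open" are said of these compounds alone.

Measured in a physicochemical assay for solubility, using the shake flask method, in simulated intestinal fluid, measured as kinetic solubility, with a stated time of 2 h, at 25 degrees C, at pH 6.5; a lower number here means a less soluble compound, a higher number a more soluble compound:
Compound 1 `Cc1noc(-c2nc(C)c3c(c2N)C(=O)N(Cc2ccccc2)C3=O)n1`: < 5000 nM (a limit)
Compound 2 `Cc1noc(-c2nc(C)c3c(c2N)C(=O)N(CC2CCOCC2)C3=O)n1`: 5700 nM
Compound 3 `COc1ccccc1CN1C(=O)c2c(C)nc(-c3nc(C)no3)c(N)c2C1=O`: < 5000 nM (a limit)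

Compound 3 is known only by a limit, and it stands at the limit of < 5000 nM in this assay, at which 2 of the 3 values shown sit. The next structure, compound 4 `Cc1noc(-c2nc(C)c3c(c2N)C(=O)N(Cc2ccncc2)C3=O)n1`, carries pyridin-4-yl in place of 2-methoxyphenyl on a saturated chain carbon bound to an amide-type nitrogen in a ring.

Two measured steps change the group at this same place. Oxan-4-yl in place of phenyl gave an at least 1.1-fold higher number from compound 1 to compound 2 (0.05 log units; that floor lies within the scatter), and 2-methoxyphenyl in place of oxan-4-yl gave an at least 1.1-fold lower number from compound 2 to compound 3 (0.05 log units; that floor lies within the scatter). Methoxy in place of hydrogen on an aromatic carbon gave a step that the two limits leave unreadable from compound 1 to compound 3. Among the measured compounds shown here, no measured compound carries pyridin-4-yl. No step beyond the scatter is therefore expected in this assay, and the estimated step is an at least 1.2-fold higher number from compound 3 to compound 4 (0.07 log units; that floor lies within the scatter). Compound 4 is expected at 6000 nM. The estimated range for it runs from 2500 nM to 20000 nM.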

Compound 4, solubility: 26400 nM
Compound 4: the middle estimate sits 4.4-fold (0.64 log units) below what was measured; the whole stated range lies below it.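

In this assay the place on a saturated chain carbon bound to an amide-type nitrogen in a ring now shows a change beyond the scatter, which no earlier pair had shown: pyridin-4-yl in place of oxan-4-yl gave a 4.6-fold higher number from compound 2 to compound 4 (0.67 log units; beyond the scatter) and is the one new step with a number at both ends. Pyridin-4-yl in place of 2-methoxyphenyl gave an at least 5.2-fold higher number from compound 3 to compound 4 (0.72 log units; beyond the scatter) and pyridin-4-yl in place of phenyl gave an at least 5.2-fold higher number from compound 1 to compound 4 (0.72 log units; beyond the scatter) at the same place. These two steps are floors and not sizes because compound 1 and compound 3 are each known only by a limit: the limit of < 5000 nM in this assay, at which 2 of the 4 values shown sit.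

The compounds shown leave open how the full size of those two steps compares with the step from compound 2. They also leave open whether the result is particular to pyridin-4-yl or would carry over to pyridin-3-yl, pyrimidin-5-yl or a piperidin-4-yl group at this place.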